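A few compounds are considered here, and "the series" means these few. Any claim that something is new, unique, unknown or untested is made for them only; others in the source may bear on it.

In an ADME assay on microsomes from liver (Homo sapiens) for metabolic stability, read by LC-MS, using NADPH, tested at 1 uM (on this read-out lower numbers stand for slow clearance and higher numbers for fast clearance), compound 1 `Cc1cnc(NC(=O)CCCOc2cccc(C#N)c2)s1` gives 172 mL.min-1.g-1 and compound 2 `CC(C)c1cnc(NC(=O)CCCOc2ccccc2)s1` gives 232 mL.min-1.g-1. Going by the values given here, these two values lie within the scatter of each other, so compound 2 cannot be set apart from compound 1, the only other compound measured so far. The next compound, compound 3 `Cc1cnc(NC(=O)CCCOc2ccccc2)s1`, comes from compound 2 through one structural change: methyl in place of isopropyl on an aromatic carbon. Methyl takes the place of isopropyl on an aromatic carbon, next to the ring sulfur, and the rest of the structure stays the same. Among the compounds with values here, no measured pair shows this exchange on its own, so the expectation rests on thin evidence. Methyl is also the group carried by compound 1, and compound 1 gives 172 mL.min-1.g-1, which points to a modest move towards a lower number, probably not beyond the scatter. The expected change is a 1.4-fold lower number from compound 2 to compound 3 (0.14 log units; within the scatter). In this assay, compound 3 is estimated at 170 mL.min-1.g-1, with an expected range of 90 mL.min-1.g-1 to 300 mL.min-1.g-1.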

Compound 3, intrinsic clearance in microsomes: 175 mL.min-1.g-1
The estimate for compound 3 lay 1.0-fold (0.01 log units) below the measured number; measured number inside the range.
By their numbers in this assay, from the lowest: compounds 1, 3 and 2 (each within the scatter of the next).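

In this assay, going by these compounds alone, this is the first pair that isolates the exchange on the aromatic carbon next to the ring sulfur: a 1.3-fold lower number from compound 2 to compound 3 (0.12 log units; within the scatter), so replacing isopropyl with methyl gives no change that can be told from the usual scatter. Compound 3 also isolates a second place in the structure, where hydrogen takes the place of cyano on an aromatic carbon, and a 1.0-fold higher number from compound 1 to compound 3 (0.01 log units; within the scatter), so this exchange likewise stays within the scatter and neither single change sets its pair apart. Nothing measured here offers an explanation for either result.

What the compounds shown leave open is whether a quite different group on the carbon next to the ring sulfur, such as an amine or a carboxylic acid, would give a step beyond the scatter in this assay. They also leave open whether a trifluoromethyl group in place of the cyano, or a longer chain in place of the one shared by all three compounds, would do so.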